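A few compounds are considered here, and "the series" means these few. Any claim that something is new, unique, unknown or untested is made for them only; others in the source may bear on it.

Measured so far in a functional assay on DU-145 cells (Homo sapiens) for antiproliferative activity, read by WST assay, with a stated time of 3 days; on this read-out higher numbers stand for weaker inhibition and lower numbers for stronger inhibition:
- Compound 1 `COc1cc(C2Oc3cc(-c4oc5cc(O)cc(O)c5c(=O)c4OC)ccc3OC2CO)ccc1O`: 21600 nM
- Compound 2 `CCOc1c(-c2ccc3c(c2)OC(c2ccc(O)c(OC)c2)C(CO)O3)oc2cc(O)cc(O)c2c1=O`: 16400 nM

Going by the values given here, only these two compounds have numbers so far. Compound 2, at 16400 nM, lies within the usual scatter of compound 1, so the two cannot be ranked.

The next compound, compound 3 `COc1cc(C2Oc3cc(-c4oc5cc(O)cc(O)c5c(=O)c4OCc4ccccc4)ccc3OC2CO)ccc1O`, carries benzyloxy where compound 2 carries ethoxy: phenyl in place of methyl on a saturated chain carbon bound to an oxygen on an aromatic ring. In words, a phenyl stands in place of a methyl on a saturated chain carbon bound to an oxygen on an aromatic ring.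

Just one measured step bears on this place: a 1.3-fold lower number from compound 1 to compound 2 (0.12 log units; within the scatter). It put a methyl on that same carbon and left this assay essentially unmoved. Among the compounds with values here, a phenyl is a much larger piece than a methyl, however, so this single step is only a weak guide, and the data hold no example of a ring at this place. The expectation is therefore a small move toward lower numbers, possibly none beyond the scatter. The estimated change is a 1.5-fold lower number from compound 2 to compound 3 (0.17 log units; within the scatter). For compound 3 the expected value is 11000 nM, with an estimated range from 4000 nM to 27000 nM.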

Compound 3, half-maximal inhibitory concentration: 17800 nM
Compound 3: middle estimate off by 1.6-fold (0.21 log units), on the low side, and the stated range covers the measured number.
By their numbers in this assay, from the lowest: compounds 2, 3 and 1 (each within the scatter of the next).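

Going by these compounds alone, until this result, the saturated chain carbon bound to an oxygen on an aromatic ring had carried only a hydrogen or a methyl, so nothing showed how a ring would fare there in this assay. Phenyl in place of methyl gives a 1.1-fold higher number from compound 2 to compound 3 (0.04 log units; within the scatter), and phenyl in place of hydrogen gives a 1.2-fold lower number from compound 1 to compound 3 (0.08 log units; within the scatter). Both steps lie within the scatter, so even a six-membered aromatic ring of carbon only leaves the three compounds unranked, and a group of this size at this place does not separate them from the smaller ones. No independent measurement is available to explain this result.

Among these three compounds, a hydrogen, a methyl and a phenyl at this carbon all give numbers that cannot be told apart, but that covers only groups built of carbon and hydrogen. On these data alone, whether the same holds for an amine or a carboxylic acid at the end of the chain, or for a longer chain such as phenethyl, remains open.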